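Swapping the ortho substituent: from ethoxy to tert-butyl

This account rests on a few compounds, and the source may have more. Where it says the series, first, only, none or still open, it means among the compounds named here.

Measured compounds:
Compound 1, `Cc1ccccc1Oc1ccc(N2CCC[C@H]2CC(=O)O)cc1` — 74 nM
Compound 2, `O=C(O)C[C@@H]1CCCN1c1ccc(Oc2ccccc2)cc1` — 560 nM
Compound 3, `CCOc1ccccc1Oc1ccc(N2CCC[C@H]2CC(=O)O)cc1` — 1700 nM

All three were tested in a functional assay on cells for agonist activity at Free fatty acid receptor 1 (Homo sapiens), read by FLIPR and calcium flux, with a stated time of 100 s; on this read-out higher numbers stand for an effect only at larger amounts of compound and lower numbers for an effect already at smaller amounts. Compound 3 has the highest number of the three: the step of a 3.0-fold higher number from compound 2 to compound 3 (0.48 log units; beyond the scatter) and the step of a 23-fold higher number from compound 1 to compound 3 (1.36 log units; beyond the scatter) both lie beyond the scatter, so compound 3 is the least potent of the measured set. The step of a 7.6-fold higher number from compound 1 to compound 2 (0.88 log units; beyond the scatter) shows that removing the methyl also weakened the response.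

Compound 4, `CC(C)(C)c1ccccc1Oc1ccc(N2CCC[C@H]2CC(=O)O)cc1`, has not yet been measured. It differs from compound 3 by tert-butyl in place of ethoxy on an aromatic carbon. Among the compounds with values here, two measured steps bear on this position: the ethoxy group gave the weakest compound, while a methyl gave the strongest, and hydrogen lay between them. A tert-butyl is neither of these, so the measured steps give only a direction, not a size. The expectation for compound 4 is a modest move toward lower numbers, a 5.7-fold lower number from compound 3 to compound 4 (0.75 log units; beyond the scatter), in this assay. Compound 4 is therefore estimated at 300 nM, with a range from 60 nM to 1500 nM.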

Compound 4, half-maximal effective concentration: 6500 nM
For compound 4 the middle estimate is 22-fold (1.34 log units) below the measured one; the whole stated range lies below it.
By their numbers in this assay, from the lowest: compound 1; then compound 2; then compound 3; then compound 4.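

In this assay, tert-butyl now marks the weak end of this position, past ethoxy (a 3.8-fold higher number from compound 3 to compound 4 (0.58 log units; beyond the scatter)) and past a bare hydrogen (a 12-fold higher number from compound 2 to compound 4 (1.06 log units; beyond the scatter)). The gap to methyl is the widest in the set (an 88-fold higher number from compound 1 to compound 4 (1.94 log units; beyond the scatter)), so a group on this aromatic carbon does not by itself bring a lower number: compound 1 alone lies below the hydrogen of compound 2, while compound 3 and compound 4 lie above it. Nothing shown here gives a reason for this order.

An ethyl group or a methoxy group would show how quickly the number rises once the position holds more than a methyl. A chlorine atom would test whether anything else can match methyl here.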